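The source may hold more compounds than are shown below. What is called first, only, known or untested is meant among the compounds shown, and "the series" means these compounds.

Of the compounds shown here, three sharing one core have been tested in a functional assay on SW620/5-FU cells (Homo sapiens) for cytotoxicity, read by MTT assay, with a stated time of 48 h, in the presence of a further agent that is not named here; on this read-out lower numbers stand for an effect already at smaller amounts and higher numbers for an effect only at larger amounts of compound. Compound 1 `Cn1ncc2c(-c3ccc(F)cc3)cc(NNC(=O)Nc3cc(Cl)nc(OCCF)c3)nc21` gives 29300 nM. Compound 2 `Cn1nc(C(F)(F)F)c2c(-c3ccccc3)cc(NNC(=O)Nc3cc(Cl)nc(Cl)c3)nc21` gives 13100 nM. Compound 3 `Cc1nn(C)c2nc(NNC(=O)Nc3cc(Cl)nc(Cl)c3)cc(-c3ccc(Cl)s3)c12` gives 29400 nM, the highest of the three numbers. Its value and that of compound 1 lie within the usual scatter of each other, so the two cannot be told apart; compound 2 sits lower by a gap that is beyond the scatter, the only clear separation among the three.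

Compound 4 `CCCc1cc(NNC(=O)Nc2cc(Cl)nc(Cl)c2)nc2c1c(C)nn2C` has not yet been measured. It differs from compound 3 in one place: propyl in place of 5-chlorothiophen-2-yl on an aromatic carbon. For the measured compounds named here, every measured compound carries a ring at this position, so there is no earlier step that shows what an open chain does here, and the three measured values all cluster at high concentrations. With nothing pointing either way, the expected step from compound 3 to compound 4 in this assay is a 1.1-fold higher number from compound 3 to compound 4 (0.04 log units; within the scatter), that is, no change beyond the scatter, with some chance that the number drifts higher. On that basis compound 4 is estimated at 32000 nM, with a range from 12000 nM to 85000 nM.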

Compound 4, half-maximal effective concentration: 40800 nM
Beside the measured number, compound 4's estimate is 1.3-fold (0.11 log units) below it, and the stated range covers the measured number.
By their numbers in this assay, from the lowest: compound 2; then compounds 1, 3 and 4 (each within the scatter of the next).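

For the compounds shown here, this is the first look at what an open chain does on this aromatic carbon, opposite the ring nitrogen: in this assay, putting propyl in place of 5-chlorothiophen-2-yl gives a 1.4-fold higher number from compound 3 to compound 4 (0.14 log units; within the scatter). Taking away the five-membered aromatic ring, with its sulfur and chlorine, therefore leaves the number indistinguishable from that of the ring-bearing parent, so for this pair a ring at this position is not required to keep the read-out where it stands, and both numbers lie at large amounts of compound. Nothing available gives a measured reason for this outcome.

This single pair cannot show whether an amine, a carboxylic acid or a longer chain such as hexyl on the same carbon would move the number beyond the usual scatter. Also open, from the compounds shown here alone, is whether the same exchange would behave alike with the other groups carried by compound 1 and compound 2, since each of them differs from compound 3 in more than one place.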